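This account rests on a few compounds, and the source may have more. Where it says the series, first, only, none or still open, it means among the compounds named here.

Working notes on the chalcone series.

Compound 1 `CC1(C)C=Cc2c(ccc(C(=O)/C=C/c3ccc(Cl)cc3)c2O)O1` and compound 2 `CC1(C)C=Cc2c(ccc(C(=O)/C=C/c3ccc(Cl)c(Cl)c3)c2O)O1` share a core and differ only in one place: chloro in place of hydrogen on an aromatic carbon. In an ADME assay on Vero cells (Chlorocebus sabaeus) for cytotoxicity, read by MTT assay, with a stated time of 72 h (on this read-out higher numbers stand for lower toxicity in this test and lower numbers for higher toxicity in this test), compound 1 gives 92200 nM, and compound 2 gives 142000 nM; the step of a 1.5-fold higher number from compound 1 to compound 2 (0.19 log units; within the scatter) is therefore small. Compound 3 `CC1(C)C=Cc2c(ccc(C(=O)/C=C/c3cnc4ccccc4c3)c2O)O1` carries a different core; the difference between the two cores is not broken down here, and for compound 3 the result in this assay is "not determined" (no result reported), so no number is available. Compound 4 `CC1(C)C=Cc2c(ccc(C(=O)/C=C/c3cc4ccccc4nc3Cl)c2O)O1` differs from compound 3 by chloro in place of hydrogen on an aromatic carbon. This is the same kind of change as from compound 1 to compound 2, though the surroundings differ: in compound 2 the chloro sits on a six-membered aromatic ring of carbon only, ortho to a chloro group and meta to a large group, whereas in compound 4 it sits on a six-membered aromatic ring with one nitrogen, part of a fused system, next to the ring nitrogen, ortho to a large group. With no number for compound 3, the expectation for compound 4 rests only on compound 1 at 92200 nM and compound 2 at 142000 nM, where the added chloro moved the read-out only within the scatter. Compound 4 is accordingly expected to give about 110000 nM in this assay, estimated between 40000 nM and 300000 nM.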

Compound 4, half-maximal cytotoxic concentration: 257000 nM
Beside the measured number, compound 4's estimate is 2.3-fold (0.37 log units) below it; low and high end bracket the measured number.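

In this assay, for the compounds shown here, compound 3 has no number, so no step to compound 4 can be read. On these data alone, whether chloro in place of hydrogen changes the read-out on this core stays open, and no measured evidence bears on the result.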